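Dropping the Ring Hydroxy: From Compound 3 to Compound 4

The source may report more compounds than this note shows. Statements on the series, on what has been measured and on what is new or still open speak of the compounds shown alone.

Of the compounds shown here, three sharing one core have been measured in an assay on Vas deferens with Adrenergic receptor alpha-1 (Rattus norvegicus) as the target; on this read-out higher numbers stand for weaker binding and lower numbers for tighter binding. Compound 1 `COc1cccc(OC)c1OCCNC[C@@H]1COc2ccccc2C1=O` carries a carbonyl on the saturated ring and gives 1.18 nM. Compound 2 `COc1cccc(OC)c1OCCNC[C@@H]1COc2ccccc2[C@@H]1O` and compound 3 `COc1cccc(OC)c1OCCNC[C@@H]1COc2ccccc2[C@H]1O` carry a hydroxy there instead; compound 2 gives 60.3 nM and compound 3 gives 46.8 nM. Compound 3 thus sits near compound 2 and far from compound 1. Within the data shown here, the only single-point step among them, a 1.3-fold lower number from compound 2 to compound 3 (0.11 log units; within the scatter), shows that flipping the configuration at that carbon changes little, which is explained by the fact that compounds 2 and 3 differ only in the configuration as drawn.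

Compound 4 `COc1cccc(OC)c1OCCNC[C@@H]1COc2ccccc2C1` is the next step: hydrogen in place of hydroxy on a saturated ring carbon. Among the measured compounds shown here, no measured step removes the hydroxy outright, so the step 2>3 is the only guide, and it suggests that the exact arrangement at this carbon matters little. The step of a 1.6-fold lower number from compound 3 to compound 4 (0.19 log units; within the scatter) is therefore expected to be modest in this assay. Compound 4 is estimated at 30 nM, with a range from 5 nM to 150 nM.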

Compound 4, dissociation constant: 10.7 nM
Beside the measured number, compound 4's estimate is 2.8-fold (0.45 log units) above it, within the range that was stated.
By their numbers in this assay, from the lowest: compound 1; then compound 4; then compounds 3 and 2 (each within the scatter of the next).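

In this assay replacing the hydroxy with hydrogen gives a 4.4-fold lower number from compound 3 to compound 4 (0.64 log units; beyond the scatter) and the same change from the other drawn configuration gives a 5.6-fold lower number from compound 2 to compound 4 (0.75 log units; beyond the scatter). So although the drawn configuration of the hydroxy made little difference, having a hydroxy on this saturated ring carbon at all goes with weaker binding than having hydrogen there, whichever way it is drawn. The carbon bearing only hydrogen does not give the lowest number, though: compound 1, with a carbonyl at this place, gives 1.18 nM and compound 4 gives 10.7 nM.

Nothing in the information at hand explains why the hydroxy goes with weaker binding here. From the compounds shown here alone, whether a methyl, a fluorine or an amine on this ring carbon would read closer to compound 4 or to the two hydroxy compounds also stays open.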